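The source may report more compounds than this note shows. Statements on the series, on what has been measured and on what is new or still open speak of the compounds shown alone.

Compound 3 `COc1ncnc2c1c(-c1ccsc1)cn2[C@@H]1O[C@H](CO)[C@@H](O)[C@H]1O` gives 430 nM in a functional assay on HepG2 cells (Homo sapiens) for antiproliferative activity, read by XTT assay, with a stated time of 72 h; a higher number here means a weaker inhibitor, a lower number a stronger inhibitor. Among the three measured compounds it holds the second-highest number. Compound 2 `COc1ncnc2c1c(-c1ccco1)cn2[C@@H]1O[C@H](CO)[C@@H](O)[C@H]1O` gives 300 nM, and the step of a 1.4-fold higher number from compound 2 to compound 3 (0.16 log units; within the scatter) lies within the scatter. Compound 1 `COc1ncnc2c1c(-c1cccs1)cn2[C@@H]1O[C@H](CO)[C@@H](O)[C@H]1O` gives 13900 nM, and the step of a 32-fold lower number from compound 1 to compound 3 (1.51 log units; beyond the scatter) lies well beyond it.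

Compound 4 `COc1ncnc2c1c(-c1cc3ccccc3o1)cn2[C@@H]1O[C@H](CO)[C@@H](O)[C@H]1O` has not yet been measured in this assay. It differs from compound 3 in one place: 1-benzofuran-2-yl in place of thiophen-3-yl on an aromatic carbon. Among the compounds with values here, none of the measured steps adds a six-membered aromatic ring of carbon only, so they bear on this change only indirectly. They show that exchanging one five-membered ring with one hetero atom for another can shift the number a great deal, as in a 46-fold lower number from compound 1 to compound 2 (1.67 log units; beyond the scatter) and a 32-fold lower number from compound 1 to compound 3 (1.51 log units; beyond the scatter), or leave it within the scatter, as in a 1.4-fold higher number from compound 2 to compound 3 (0.16 log units; within the scatter). Compound 4 keeps the furan ring found in compound 2, which gives 300 nM. The expected step is a 1.2-fold lower number from compound 3 to compound 4 (0.09 log units; within the scatter), within the scatter. Compound 4 is therefore estimated at 350 nM, with a range from 100 nM to 1500 nM.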

Compound 4, half-maximal inhibitory concentration: > 20000 nM
Compound 4: no number, only a limit (the forecaster's own chance of this, stated with the estimate: 5%); at least 57-fold (1.75 log units) between middle value and limit.
By their numbers in this assay, from the lowest: compounds 2 and 3 (each within the scatter of the next); then compound 1. At a limit, above all of these: compound 4.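

Compound 4 has no number in this assay, only a limit: the limit of > 20000 nM in this assay, at which 1 of the 4 values shown sits.

Even so, the earlier compounds showed only swaps of one five-membered ring for another, and this change shows that the number can also rise well beyond the scatter when the group at this position is 1-benzofuran-2-yl, which carries a six-membered aromatic ring of carbon only, with an at least 66-fold higher number from compound 2 to compound 4 (1.82 log units; beyond the scatter) and an at least 46-fold higher number from compound 3 to compound 4 (1.66 log units; beyond the scatter). The remaining step, an at least 1.4-fold higher number from compound 1 to compound 4 (0.15 log units; that floor lies within the scatter), has a floor that lies within the scatter, and compound 1, with its single ring of thiophen-2-yl, shows that a high number here does not require the added ring.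

The compounds shown leave open whether a six-membered aromatic ring is a problem at this carbon on its own, as a plain phenyl group would show. They also leave open whether a group carrying an amine would behave differently.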